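The source may hold more compounds than are shown below. What is called first, only, known or untested is meant among the compounds shown, and "the series" means these compounds.

Compound 1 `O=C(Nc1ccccn1)c1c(O)c2cccnc2n(-c2ccccc2)c1=O`: 14.6%. Compound 2 `CNC(=O)c1c(O)c2cccnc2n(-c2ccccc2)c1=O`: 21%. Compound 3 `O=C(NN1CCOCC1)c1c(O)c2cccnc2n(-c2ccccc2)c1=O`: -26.2%.

All three were tested in a functional assay on the whole organism for inhibition, with Rattus norvegicus as the target, read by cytopathic effect and paw edema, at a dose of 100 mg/kg by the oral route; a higher number here means more inhibition at the dose given (going by the name of the read-out), a lower number less inhibition. Compound 3 stands lowest of the three measured numbers, with compound 1 nearest and compound 2 furthest, both gaps beyond the scatter. Compound 4 `COc1ccc(NC(=O)c2c(O)c3cccnc3n(-c3ccccc3)c2=O)cc1` has not been measured; it differs from compound 3 by 4-methoxyphenyl in place of morpholin-4-yl on an amide-type nitrogen. Among the compounds with values here, the steps that bear on this are a number 40.8 percentage points lower from compound 1 to compound 3 (beyond the scatter) and a number 47.2 percentage points lower from compound 2 to compound 3 (beyond the scatter), both large and both running away from the morpholin-4-yl group. Compound 4 is expected to move back up, because a number 40.8 percentage points lower from compound 1 to compound 3 (beyond the scatter) was large and compound 1 likewise bears a six-membered aromatic ring on that nitrogen, so the expected step is a number 41.2 percentage points higher from compound 3 to compound 4 (beyond the scatter). Compound 4 is estimated at 15%, within a range of -5% to 35%.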

Compound 4, a percentage reported as inhibition, in the whole organism at one dose (the size of the read-out at that dose, not a potency): -1.9%
Compound 4: the middle estimate sits 16.9 percentage points above what was measured, and the stated range covers the measured number.
By their numbers in this assay, from the lowest: compound 3; then compound 4; then compounds 1 and 2 (each within the scatter of the next).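

In this assay, 4-methoxyphenyl on the amide-type nitrogen regains only part of the ground lost with morpholin-4-yl, with a number 24.3 percentage points higher from compound 3 to compound 4 (beyond the scatter). It still falls short of the smaller methyl group, with a number 22.9 percentage points lower from compound 2 to compound 4 (beyond the scatter), and of the other aromatic group, pyridin-2-yl, with a number 16.5 percentage points lower from compound 1 to compound 4 (beyond the scatter), so a six-membered aromatic ring at this place does not alone set the number. Nothing on hand accounts for these steps.

Open, as far as these compounds go, is where an unsubstituted phenyl, or a longer chain ending in a dimethylamino group, would fall on that nitrogen.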